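The compounds below may be only part of what the source reports. "The series", "measured", "known", "first", "only" and "open" are said of these compounds alone.

Compound 2 `Cc1c(C(=O)N/N=C\c2cccc(O)c2O)oc2cccc(O)c12` is the stronger of the two measured compounds. In a functional assay on MGC-803 cells (Homo sapiens) for inhibition, read by MTT assay (on this read-out lower numbers stand for stronger inhibition and higher numbers for weaker inhibition), compound 2 gives 5030 nM, while compound 1 `Cc1c(C(=O)N/N=C\c2c(O)cccc2F)oc2cccc(O)c12` gives 10800 nM. For the measured compounds named here, the one measured step runs a 2.1-fold lower number from compound 1 to compound 2 (0.33 log units; beyond the scatter), and it exchanges a ring that carries a fluoro and a hydroxy for one that carries two hydroxy groups.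

Compound 3 `Cc1c(C(=O)N/N=C\c2cccc(F)c2O)oc2cccc(O)c12` takes the opposite direction. Its change is fluoro in place of hydroxy on an aromatic carbon, so a hydroxy goes out and a fluoro comes in on an aromatic carbon of a six-membered aromatic ring of carbon only, ortho to a hydroxy group and meta to a large group. The step from compound 1 to compound 2 is the only one that bears on this, and it was modest and beyond the scatter. Because that step was a 2.1-fold lower number from compound 1 to compound 2 (0.33 log units; beyond the scatter), a swap back toward fluoro is expected to give a modestly higher number in this assay, though the fluoro now sits at a different place on the ring, so the size is uncertain. Compound 3 is therefore expected at 8000 nM, with a likely range from 3500 nM to 20000 nM, a step of a 1.6-fold higher number from compound 2 to compound 3 (0.20 log units; within the scatter).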

Compound 3, half-maximal inhibitory concentration: 8350 nM
Beside the measured number, compound 3's estimate is 1.0-fold (0.02 log units) below it; measured number inside the range.
By their numbers in this assay, from the lowest: compounds 2, 3 and 1 (each within the scatter of the next, the first and the last beyond it).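

In this assay the exchange of hydroxy for fluoro on this one aromatic carbon, with nothing else altered, gives a 1.7-fold higher number from compound 2 to compound 3 (0.22 log units; within the scatter) and so the two groups cannot be told apart here, even though the hydroxy counts a hydrogen-bond donor and acceptor and the fluoro counts neither. The earlier step changed the ring in more than one place at once, whereas this one isolates a single group, and the exchange of 2-fluoro-6-hydroxyphenyl for 3-fluoro-2-hydroxyphenyl gives a 1.3-fold lower number from compound 1 to compound 3 (0.11 log units; within the scatter) and so also stays within the scatter. Nothing available explains why these numbers fall as they do.

On these data alone, what a methoxy group, a chloro group or an amine would do on this same carbon stays open, as does the effect of a carboxylic acid, a group much larger than the fluoro and hydroxy seen so far. Also open, as far as these compounds go, is whether the closeness of hydroxy and fluoro here would hold on cells other than those of this single assay.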